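The source may report more compounds than this note shows. Statements on the series, on what has been measured and on what is new or still open speak of the compounds shown alone.

Measured compounds:
Compound 1, `Cc1cccc(N2CC(C)NC(=O)N2)c1`, gives 19000 nM
Compound 2, `CC1CN(c2ccccc2)NC(=O)N1O`, gives 6000 nM
Compound 3, `CC1CN(c2cccc(Cl)c2)NC(=O)N1O`, gives 3900 nM

All three numbers come from an assay on RBL-1 cells for inhibition of Polyunsaturated fatty acid 5-lipoxygenase (Rattus norvegicus); a lower number here means a stronger inhibitor, a higher number a weaker inhibitor. Among them compound 3 has the lowest number. Its neighbour is compound 2, and the gap between the two is a 1.5-fold lower number from compound 2 to compound 3 (0.19 log units; within the scatter), so the pair cannot be told apart with confidence. Compound 1, which carries no hydroxyl on the ring nitrogen of the shared core, stands furthest away, and that gap is beyond the scatter.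

The next compound, compound 4, is `Cc1cccc(N2CC(C)N(O)C(=O)N2)c1`. It differs from compound 3 in one place: methyl in place of chloro on an aromatic carbon. For the measured compounds named here, the only measured step that touches the same aromatic carbon is the one from compound 2 to compound 3, where adding chloro in place of hydrogen moved the number by a 1.5-fold lower number from compound 2 to compound 3 (0.19 log units; within the scatter), within the scatter. Swapping one small group for another at that carbon therefore gives no reason to expect a shift beyond the scatter in this assay, in either direction.

Compound 4 is accordingly expected to land near compound 3, with an estimated value of 4500 nM, somewhere between 2000 nM and 12000 nM, which corresponds to an expected step of a 1.2-fold higher number from compound 3 to compound 4 (0.06 log units; within the scatter).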

Compound 4, half-maximal inhibitory concentration: 8400 nM
Beside the measured number, compound 4's estimate is 1.9-fold (0.27 log units) below it; the measured number falls inside the stated range.
By their numbers in this assay, from the lowest: compounds 3, 2 and 4 (each within the scatter of the next, the first and the last beyond it); then compound 1.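

In this assay the aromatic carbon now shows a first, limited sensitivity: methyl in place of chloro gives a 2.2-fold higher number from compound 3 to compound 4 (0.33 log units; beyond the scatter) and counts as a modest step, whereas methyl in place of hydrogen gives a 1.4-fold higher number from compound 2 to compound 4 (0.15 log units; within the scatter) and leaves that pair indistinguishable. Chloro and methyl therefore separate only when compared directly, since each of these two compounds lies within the scatter of compound 2, the hydrogen compound. For the compounds shown here, compound 4 also supplies the first pair that isolates the hydroxy on the amide-type nitrogen in the ring, with the aromatic methyl unchanged: this change gives a 2.3-fold lower number from compound 1 to compound 4 (0.35 log units; beyond the scatter) and is also modest.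

Still open, from the compounds shown here alone, is whether an amine, a carboxylic acid or a longer chain on this aromatic carbon would move the number further, and whether the hydroxy change would have a similar size with chloro or hydrogen on the aromatic ring. Nothing in the available data gives a measured explanation for any of these steps.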